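Replacing cyclopentyl with 2-chlorophenyl on the amino nitrogen

A few compounds are considered here, and "the series" means these few. Any claim that something is new, unique, unknown or untested is made for them only; others in the source may bear on it.

Compound 1 `O=C(Nc1ccc(Nc2nccc(NC3CCCC3)n2)cc1)Nc1ccc(Cl)c(C(F)(F)F)c1`: 5880 nM
Compound 2 `O=C(Nc1ccc(Nc2nccc(NC3CC3)n2)cc1)Nc1ccc(Cl)c(C(F)(F)F)c1`: 18500 nM
Compound 3 `O=C(Nc1ccc(Nc2nccc(Nc3ccccc3)n2)cc1)Nc1ccc(Cl)c(C(F)(F)F)c1`: > 50000 nM, a limit of the assay

In a functional assay on A549 cells (Homo sapiens) for antiproliferative activity, read by MTT assay, with a stated time of 72 h (on this read-out higher numbers stand for weaker inhibition and lower numbers for stronger inhibition), compound 1 gives 5880 nM, the lower of the two actual numbers, and compound 2 gives 18500 nM. Compound 3 reaches only a limit, > 50000 nM.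

Compound 4 `O=C(Nc1ccc(Nc2nccc(Nc3ccccc3Cl)n2)cc1)Nc1ccc(Cl)c(C(F)(F)F)c1` has not yet been measured. It keeps the core of compound 1 and carries 2-chlorophenyl in place of cyclopentyl on a nitrogen on an aromatic ring.

The closest measured change, phenyl in place of cyclopentyl, gave an at least 8.5-fold higher number from compound 1 to compound 3 (0.92 log units; beyond the scatter). Cyclopropyl in place of cyclopentyl gave a 3.1-fold higher number from compound 1 to compound 2 (0.50 log units; beyond the scatter), and phenyl in place of cyclopropyl gave an at least 2.7-fold higher number from compound 2 to compound 3 (0.43 log units; beyond the scatter). Going by these compounds, both phenyl steps end at the limit of > 50000 nM in this assay, at which 1 of the 3 values shown sits, so their full size remains open. Going by the values given here, no measured compound carries a chlorine on this phenyl ring, which leaves its contribution unknown.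

With compound 3 as the nearest guide, through an at least 8.5-fold higher number from compound 1 to compound 3 (0.92 log units; beyond the scatter), a step of similar size towards a higher number is expected in this assay. The estimated change is a 5.1-fold higher number from compound 1 to compound 4 (0.71 log units; beyond the scatter). Compound 4 is expected to read about 30000 nM, with an estimated range from 10000 nM to 70000 nM.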

Compound 4, half-maximal inhibitory concentration: 18600 nM
Beside the measured number, compound 4's estimate is 1.6-fold (0.21 log units) above it; low and high end bracket the measured number.
By their numbers in this assay, from the lowest: compound 1; then compounds 2 and 4 (each within the scatter of the next). At a limit, above all of these: compound 3.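

In this assay, going by these compounds alone, a phenyl ring on this amino nitrogen does not have to end at the limit of the assay: chloro in place of hydrogen on an aromatic carbon gives an at least 2.6-fold lower number from compound 3 to compound 4 (0.42 log units; beyond the scatter), the first readable number for an aromatic group at this place. Compound 3 stands at a limit, so this step has a minimum size but no full size: the limit of > 50000 nM in this assay, at which 1 of the 4 values shown sits. Even with the chlorine, the aromatic group does not reach the number of the cyclopentyl compound, with a 3.2-fold higher number from compound 1 to compound 4 (0.50 log units; beyond the scatter), while 2-chlorophenyl and cyclopropyl cannot be told apart on this nitrogen, with a 1.0-fold higher number from compound 2 to compound 4 (0.00 log units; within the scatter).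

Going by these compounds, whether fluoro, methyl or methoxy on the phenyl ring would act as chloro does, or whether this step is particular to chlorine, stays open. On these data alone, it is also open how a cyclohexyl ring, an open chain such as isopropyl or a ring holding a further amine, such as piperidine, would compare with cyclopentyl at this place.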